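The compounds below may be only part of what the source reports. "The series", "measured", "known", "first", "only" and "open" are said of these compounds alone.

Compound 2, `C[C@@H](NC(=O)Nc1cccc(Br)c1)c1ccccc1`, is a urea in which one nitrogen carries a bromo-substituted phenyl ring. In an ADME assay on the whole organism with Oryza sativa as the target, tested at 1 uM (a higher number here means a weaker effect of the compound at the concentration tested, a lower number a stronger effect), compound 2 gives 100%, the higher of the two numbers in hand. Compound 1, `CC(C)c1cccc(NC(=O)N[C@H](C)c2ccccc2)c1`, carries an isopropyl group in place of the bromo and gives 61%. Among the compounds with values here, the single measured step, a number 39 percentage points higher from compound 1 to compound 2 (beyond the scatter), is the only guide here, and it compares two rather different groups. Compound 3, `C[C@@H](NC(=O)Nc1cccc(I)c1)c1ccccc1`, is changed from compound 2 by iodo in place of bromo on an aromatic carbon. This swap of one halogen for another is a smaller structural move than the isopropyl-to-bromo step, so no step beyond the scatter is expected; the value of compound 3 is estimated to sit close to that of compound 2, with a number 5 percentage points lower from compound 2 to compound 3 (within the scatter). For compound 3, the expected value is 95%, within a range from 75% to 100%.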

Compound 3, a percentage reported as activity, at one concentration (the size of the read-out at that concentration, not a potency): 75%
Compound 3: the middle estimate sits 20 percentage points above what was measured; the measured number falls inside the stated range.
By their numbers in this assay, from the lowest: compound 1; then compound 3; then compound 2.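

At this aromatic carbon, meta to a large group, one halogen cannot simply stand in for another: in this assay there is a number 25 percentage points lower from compound 2 to compound 3 (beyond the scatter), so iodo gives a stronger effect than bromo at the concentration tested. Iodo still does not match isopropyl, with a number 14 percentage points higher from compound 1 to compound 3 (beyond the scatter), which leaves compound 1 with the strongest effect of the three compounds. Nothing available explains why these groups differ.

As far as these compounds go, whether the order isopropyl, iodo, bromo reflects a trend or just three separate results remains open, and a chloro, methyl or tert-butyl group at the same carbon would help to decide this. From the compounds shown here alone, it is also open whether the difference between iodo and bromo would hold at another carbon of the ring.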